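The compounds below may be only part of what the source reports. "The series", "measured", "known", "first", "only" and "open" are said of these compounds alone.

Values in a functional assay on MDA-MB-231 cells (Homo sapiens) for antiproliferative activity, read by MTT assay, with a stated time of 48 h; a lower number here means a stronger inhibitor, a higher number a weaker inhibitor:
- compound 1 `COc1ccc(N(C)c2ccnc(Cl)n2)cc1F`: 1280 nM
- compound 2 `COc1ccc(N(C)c2ccnc(Cl)n2)cc1Cl`: 1380 nM
- compound 3 `COc1ccc(N(C)c2ccnc(Cl)n2)cc1OCCCBr`: 1280 nM

These three values show no real separation: no change at the digits printed from compound 1 to compound 3 (within the scatter), and a 1.1-fold lower number from compound 2 to compound 3 (0.03 log units; within the scatter). The next structure is compound 4 `COc1ccc(N(C)c2ccnc(Cl)n2)cc1OCCCCC[Se]C#N`, with this difference: a group of 5 heavy atoms (3 carbon, 1 nitrogen, 1 selenium; no ring) in place of one bromine atom, on a saturated chain carbon, three bonds along the chain from an oxygen on an aromatic ring. The change lies on a saturated chain carbon, three bonds along the chain from an oxygen on an aromatic ring.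

Among the compounds with values here, the only measured steps that bear on it are indirect. Besides the two above, there is a 1.1-fold higher number from compound 1 to compound 2 (0.03 log units; within the scatter). All three exchange a group on an aromatic carbon, all are small, and all lie within the scatter. Within the data shown here, no measured step replaces the bromine, so the series offers no direct read on this change. On this limited evidence, no shift beyond the scatter is expected in this assay, with only a slight lean towards a lower number. The expected change is a 1.4-fold lower number from compound 3 to compound 4 (0.15 log units; within the scatter). Compound 4 is estimated at 900 nM, with an expected range of 200 nM to 2500 nM. The range is kept wide for lack of a direct precedent.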

Compound 4, half-maximal inhibitory concentration: > 10000 nM
Compound 4 was reported as a limit; the forecaster's own chance of this, stated with the estimate: 3%; middle value at least 11-fold (1.04 log units) away from the limit.
By their numbers in this assay, from the lowest: compounds 1, 3 and 2 (each within the scatter of the next). At a limit, above all of these: compound 4.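

Compound 4 is reported only as a limit in this assay, > 10000 nM, and not as a number. Within the data shown here, on a saturated chain carbon, three bonds along the chain from an oxygen on an aromatic ring, the group of 5 heavy atoms in place of bromo gives an at least 7.8-fold higher number from compound 3 to compound 4 (0.89 log units; beyond the scatter), the only step beyond the scatter, whereas the exchanges on an aromatic carbon among compounds 1, 2 and 3 all lie within it. The full size of this step cannot be read, as only its lower bound is fixed: the limit of > 10000 nM in this assay, at which 1 of the 4 values shown sits.

The step changes the chain and its end group at once, so the shift cannot be assigned to the added carbons, the selenium or the nitrile. A bromo group on the longer chain, or an amine or a carboxylic acid at this place, would help separate these parts.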